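Shifting two chlorines on a benzyl ether

The source may hold more compounds than are shown below. What is called first, only, known or untested is meant among the compounds shown, and "the series" means these compounds.

In a functional assay on MCF7 cells (Homo sapiens) for inhibition, read by MTT assay, with a stated time of 72 h (a higher number here means a weaker inhibitor, a lower number a stronger inhibitor), compound 1 `C=CCc1ccc(OCc2c(Cl)cccc2Cl)c(-c2ccc(OCc3c(Cl)cccc3Cl)c(CC=C)c2)c1` is recorded as > 50000 nM, which is a limit and not a number.

Compound 2 `C=CCc1ccc(O)c(-c2ccc(OCc3ccc(Cl)c(Cl)c3)c(CC=C)c2)c1` gives 15300 nM in this assay. For the measured compounds named here, this is the only true number so far, so compound 2 cannot yet be placed in a ranking of measured values.

Compound 3 `C=CCc1ccc(O)c(-c2ccc(OCc3c(Cl)cccc3Cl)c(CC=C)c2)c1` has the same atoms as compound 2, joined differently: 2,6-dichlorophenyl in place of 3,4-dichlorophenyl on a saturated chain carbon bound to an oxygen on an aromatic ring. Put simply, 2,6-dichlorophenyl stands in place of 3,4-dichlorophenyl on a saturated chain carbon bound to an oxygen on an aromatic ring. The benzyl group keeps both its chlorines, and only their positions change.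

Going by the values given here, no measured pair of compounds isolates this change, so nothing yet shows how large its effect in this assay will be. Without such a guide, the expectation is no shift beyond the usual scatter, with a wide margin of uncertainty, especially toward weaker inhibition. The step expected is a 1.0-fold higher number from compound 2 to compound 3 (0.02 log units; within the scatter). For compound 3 the estimated value is 16000 nM, with an expected range of 6000 nM to 45000 nM.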

Compound 3, half-maximal inhibitory concentration: 11500 nM
Compound 3: the middle estimate sits 1.4-fold (0.14 log units) above what was measured; the measured number falls inside the stated range.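

Moving the two chlorines around the benzyl ring, from the 3,4-dichlorophenyl to the 2,6-dichlorophenyl arrangement, gives a 1.3-fold lower number from compound 2 to compound 3 (0.12 log units; within the scatter) in this assay, so for this pair the placement of the chlorines leaves the read-out within the normal spread of repeated measurements. For the compounds shown here, the other new comparison concerns a different change, with hydrogen replacing one of the two 2,6-dichlorobenzyl groups on an oxygen on an aromatic ring, and it gives an at least 4.3-fold lower number from compound 1 to compound 3 (0.63 log units; beyond the scatter), the only step so far that clearly exceeds the scatter. Compound 1 is recorded only as a limit, so this step has a minimum size but no known full size: the limit of > 50000 nM in this assay, at which 1 of the 3 values shown sits.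

As far as these compounds go, what a plain benzyl group, with no chlorine at all, or a benzyl group carrying a carboxylic acid would do on this oxygen remains open, so the pair of compounds 2 and 3 cannot show whether the chlorines contribute anything to the read-out. From the compounds shown here alone, it is also open whether a methyl in place of the hydrogen on the oxygen of compound 3 would keep the value of compound 3 or move it toward the limit of compound 1.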